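Swapping a Pyridine for a Chlorofluorophenyl Ring

The source may report more compounds than this note shows. Statements on the series, on what has been measured and on what is new or still open speak of the compounds shown alone.

Four close relatives share one core and differ only in the aromatic rings hung on it. In a functional assay on BJAB cells (Homo sapiens) for antiproliferative activity, with a stated time of 4 days (a lower number here means that less compound is needed, a higher number that more compound is needed for the effect), compound 1 `COc1ccc(C)cc1-c1c(C)nn(-c2nc(-c3ccc(Cl)c(Cl)c3)c(SC(C)C)s2)c1C(=O)O` gives 9500 nM, and compound 2 `Cc1c(-c2cc(Cl)cc(Cl)c2)c(C(=O)O)nn1-c1nc(-c2cc(Cl)cc(Cl)c2)c(SC(C)C)s1` gives 2000 nM. Compound 3 `Cc1c(-c2cc(Cl)cc(Cl)c2)c(C(=O)O)nn1-c1nc(-c2ccncc2)c(SC(C)C)s1` was reported as "not active" (no number reported) in this assay, with no number attached, so it stands without a value. Compound 4 `Cc1c(-c2cc(Cl)cc(Cl)c2)c(C(=O)O)nn1-c1nc(-c2cc(Cl)ccc2F)c(SC(C)C)s1` differs from compound 3 in one place: 5-chloro-2-fluorophenyl in place of pyridin-4-yl on an aromatic carbon. Among the compounds with values here, no measured step ties this change to a number; the nearest guide is compound 2, whose 2000 nM is the only number for a carbon-only ring at that place. Moving from inactive compound 3, a gain is expected. Compound 4 is expected to give about 6000 nM, between 1500 nM and 30000 nM.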

Compound 4, half-maximal effective concentration: 4800 nM
Compound 4: the middle estimate sits 1.3-fold (0.10 log units) above what was measured; low and high end bracket the measured number.
By their numbers in this assay, from the lowest: compound 2; then compounds 4 and 1 (each within the scatter of the next).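

Compound 3, with pyridin-4-yl, was reported as not active in this assay, whereas compound 4, with a carbon-only ring at the same place, gives a number. That ring's substituents also matter, though modestly: 5-chloro-2-fluorophenyl in place of 3,5-dichlorophenyl gives a 2.4-fold higher number from compound 2 to compound 4 (0.38 log units; beyond the scatter). Nothing available here explains either difference.

On these data alone, it remains open whether a plain phenyl ring or a chlorine-bearing pyridine ring at this place would give a number. How a methoxy group or an amine on the ring would compare is also unknown.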